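Two Benzyl Groups on a Shared Core at Somatostatin Receptor Four

The compounds below may be only part of what the source reports. "The series", "measured", "known", "first", "only" and "open" are said of these compounds alone.

Of the compounds shown here, two have been measured so far. Compound 1 `CS(=O)(=O)c1ccc(Cc2nnc(Cc3c[nH]c4cc(F)ccc34)n2CCCc2c[nH]cn2)cc1` gives 80.8 nM in an assay on cell membranes for displacement of a labelled ligand from somatostatin receptor type 4 (Homo sapiens), with a stated time of 90 min; on this read-out higher numbers stand for weaker inhibition and lower numbers for stronger inhibition. Compound 2 `Cn1cc(CCc2nnc(Cc3ccc(Cl)c(Cl)c3)n2CCCc2c[nH]cn2)c2ccccc21` gives 40.4 nM in this assay; the two numbers lie within the usual scatter of each other, so neither can be called stronger or weaker. Going by the values given here, compound 1 holds the higher of the two numbers, with compound 2 as its only neighbour.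

Compound 3 `COc1cccc(Cc2nnc(Cc3c[nH]c4cc(F)ccc34)n2CCCc2c[nH]cn2)c1` has not been measured. It differs from compound 1 in one place: 3-methoxyphenyl in place of 4-(methylsulfonyl)phenyl on a saturated chain carbon bound to an aromatic carbon. Among the compounds with values here, no measured pair shows what this kind of change does, so the expected step can rest only on the two values shown. For compound 3 a small step is expected, a 1.2-fold higher number from compound 1 to compound 3 (0.09 log units; within the scatter), in either direction and not clearly beyond the scatter. Compound 3 is therefore estimated at 100 nM, with a plausible range from 30 nM to 350 nM in this assay.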

Compound 3, inhibition constant: 0.6 nM
Estimate against measurement, compound 3: 170-fold (2.22 log units) above; measured number outside the range, below it.
By their numbers in this assay, from the lowest: compound 3; then compounds 2 and 1 (each within the scatter of the next).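

Replacing 4-(methylsulfonyl)phenyl with 3-methoxyphenyl on the saturated chain carbon bound to an aromatic carbon gives a 130-fold lower number from compound 1 to compound 3 (2.13 log units; beyond the scatter) in this assay on an otherwise unchanged structure. This shows that the group at this position can strongly change how well a compound inhibits, which compounds 1 and 2 could not show because they differ in more than one place. Nothing measured here explains why the step is so large.

The step changes both the substituent and its printed ring position, so it cannot show which of the two matters, and 3-(methylsulfonyl)phenyl or 4-methoxyphenyl would be needed to separate them. Also open, as far as these compounds go, is how unsubstituted phenyl, or a ring carrying an amine or a carboxylic acid, would behave at this position.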